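From a Fluorophenyl Ether to a Pyridyl Ether

The source may report more compounds than this note shows. Statements on the series, on what has been measured and on what is new or still open speak of the compounds shown alone.

Compound 1, `C=CC(=O)NCc1coc(-c2c(N)ncnc2Nc2ccc(Oc3cc(Cl)ccc3Cl)c(Cl)c2)n1`, gives 1.6 h in an in vitro ADME assay on microsomes from liver (Homo sapiens) for metabolic stability, tested at 5 uM; on this read-out lower numbers stand for a shorter-lived compound and higher numbers for a longer-lived compound.
Compound 2, `C=CC(=O)NCc1coc(-c2c(N)ncnc2Nc2ccc(Oc3ccc(F)cc3)c(Cl)c2)n1`, reaches > 1.66 h in this assay, which is a limit of the measurement rather than a number.

Compound 2 therefore stands at the upper edge of what this assay reports, as the limit of > 1.66 h in this assay, at which 1 of the 2 values shown sits, shows. For the measured compounds named here, the only measured step, an at least 1.0-fold higher number from compound 1 to compound 2 (0.01 log units; that floor lies within the scatter), swapped one aryl group on the ether oxygen for another and lies within the scatter, so it gives no sign that the group on that oxygen moves the half-life much.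

Compound 3, `C=CC(=O)NCc1coc(-c2c(N)ncnc2Nc2ccc(Oc3ccccn3)c(Cl)c2)n1`, carries the change (pyridin-2-yl in place of 4-fluorophenyl on an oxygen on an aromatic ring). This is again a swap of one six-membered aromatic group for another at the same oxygen. Going by the values given here, no measured step covers a pyridin-2-yl group, so the expectation rests on the flat step from compound 1 to compound 2 alone. Compound 3 is expected to sit near compound 2, with a step that the limit leaves unreadable from compound 2 to compound 3 that stays within the scatter. The half-life of compound 3 in this assay is estimated at 1.7 h, within 0.8 h to 3.5 h.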

Compound 3, half-life: 0.65 h
Beside the measured number, compound 3's estimate is 2.6-fold (0.42 log units) above it; measured number outside the range, below it.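

The group on the ether oxygen turns out to matter for the half-life in this assay: exchanging one carbon-only ring for another gave no readable change, but the move to pyridin-2-yl gives an at least 2.5-fold lower number from compound 2 to compound 3 (0.40 log units; beyond the scatter). The comparison with the 2,5-dichlorophenyl group points the same way, with a 2.5-fold lower number from compound 1 to compound 3 (0.39 log units; beyond the scatter), and this step has a measured number at both ends. Compound 2 carries a limit of the assay and not a number, so the step that starts from it is only a floor: the limit of > 1.66 h in this assay, at which 1 of the 3 values shown sits.

Compound 3 differs from compound 1 and compound 2 both by the nitrogen in its ring and by having no halogen on that ring, so these compounds cannot show which of the two differences goes with the shorter half-life, and they give no cause for it. A plain phenyl group on the same oxygen would help to separate the two, while pyridin-3-yl and pyridin-4-yl groups would test whether the drop is particular to pyridin-2-yl or is shared by other pyridyl ethers.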